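Aryl for octyl on the triazole nitrogen

The source may hold more compounds than are shown below. What is called first, only, known or untested is meant among the compounds shown, and "the series" means these compounds.

Measured compounds:
compound 1, `CCCCCCCCn1cc(CO[C@H]2CC(=O)[C@@H]3OC[C@H]2O3)nn1`: > 50000 nM
compound 2, `O=C1C[C@H](OCc2cn(-c3cccc4ccccc34)nn2)[C@H]2CO[C@@H]1O2`: 21900 nM

Both compounds share the same core and carry a group on an aromatic nitrogen of the five-membered ring with three nitrogens; both were tested in a functional assay on MDA-MB-231 cells (Homo sapiens) for cytotoxicity, read by MTT assay, with a stated time of 48 h; on this read-out lower numbers stand for stronger inhibition and higher numbers for weaker inhibition. In this assay compound 1 gives > 50000 nM, which is a limit of the assay and not a number. Compound 2, with a naphthalenyl on that nitrogen, gives 21900 nM. Compound 1 thus stands only at the limit of > 50000 nM in this assay, at which 1 of the 2 values shown sits, so where it truly sits on the scale is not known.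

Compound 3, `O=C1C[C@H](OCc2cn(-c3cccc(Cl)c3Cl)nn2)[C@H]2CO[C@@H]1O2`, has not yet been measured. It differs from compound 1 by 2,3-dichlorophenyl in place of octyl on an aromatic nitrogen. Among the measured compounds shown here, no step between measured compounds fixes the size of this change. Since compound 1 is only a limit, the step from it to compound 3 is expected to run toward stronger inhibition, and its expected size is an at least 2.0-fold lower number from compound 1 to compound 3 (0.30 log units; that floor lies within the scatter). Compound 3 is expected to give about 25000 nM, within a range from 8000 nM to 60000 nM, the aryl-bearing compound 2 at 21900 nM being the nearest guide.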

Compound 3, half-maximal inhibitory concentration: 26000 nM
The estimate for compound 3 lay 1.0-fold (0.02 log units) below the measured number; measured number inside the range.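

In this assay, 2,3-dichlorophenyl in place of octyl on the aromatic nitrogen gives an at least 1.9-fold lower number from compound 1 to compound 3 (0.28 log units; that floor lies within the scatter), so the change can be read only as a floor, and a small one at that. What the result adds is a second aryl group at this position that gives a number rather than a limit: compound 2, with naphthalenyl, gives 21900 nM, and compound 3, with 2,3-dichlorophenyl, gives 26000 nM, two values that lie within the usual scatter of each other. Compound 1 remains a limit of the assay and not a number: the limit of > 50000 nM in this assay, at which 1 of the 3 values shown sits.

The true size of the step away from octyl therefore stays unknown, and the compounds shown cannot tell whether the aromatic ring itself or the two chlorines matter for the value of compound 3. Also open, going by these compounds, is what a plain phenyl, a benzyl group or a shorter chain such as butyl on that nitrogen would give, and whether an amine or a carboxylic acid on the phenyl ring would move the number at all.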